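A few compounds are considered here, and "the series" means these few. Any claim that something is new, unique, unknown or untested is made for them only; others in the source may bear on it.

Measured so far:
compound 1 `CCn1ncc2c(F)cc(-c3ccc(C(CC)(CC)c4nnc[nH]4)c(=O)[nH]3)cc21`, in an ADME assay on microsomes from liver (Homo sapiens) for metabolic stability (a lower number here means that the compound disappears faster, a higher number that the compound lasts longer), compound 1 gives 2.7 h
compound 2 `Cc1nc(C(c2ccc(-c3ccc4cccc(F)c4c3)[nH]c2=O)C(C)C)[nH]c1C`, in this assay compound 2 gives 0.268 h

Compound 2 holds the lower of the two numbers; compound 1 stands above it, and that gap lies beyond the usual scatter of repeated measurements. Compound 3 `CC(C)C(CC(N)=O)c1ccc(-c2ccc3cccc(F)c3c2)[nH]c1=O` has not yet been measured in this assay. It differs from compound 2 in one place: carbamoylmethyl in place of 4,5-dimethyl-1H-imidazol-2-yl on a saturated chain carbon bound to an aromatic carbon and a saturated chain carbon. Within the data shown here, no step between two measured compounds covers this exchange, so there is no measured guide to its size or direction. Among the measured compounds shown here, because the only measured neighbour is compound 2 with 0.268 h, the expectation rests on that number alone, and the step is expected to be modest: a 1.5-fold higher number from compound 2 to compound 3 (0.17 log units; within the scatter), with the direction uncertain. For compound 3 the expected half-life is 0.4 h, with a likely range from 0.15 h to 1.2 h.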

Compound 3, half-life: < 0.0667 h
Compound 3: a limit, no number; the forecaster's own chance of this, stated with the estimate: 5%; middle value at least 5.9-fold (0.77 log units) away from the limit.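

For this assay, compound 3 reaches a limit of the assay and not a number: the limit of < 0.0667 h in this assay, at which 1 of the 3 values shown sits.

Even so, the change has a readable direction and a minimum size at this saturated chain carbon bound to an aromatic carbon and a saturated chain carbon: carbamoylmethyl in place of 4,5-dimethyl-1H-imidazol-2-yl gives an at least 4.0-fold lower number from compound 2 to compound 3 (0.60 log units; beyond the scatter). This shows that the half-life depends on the group at this position, and that of these two groups, 4,5-dimethyl-1H-imidazol-2-yl gives the longer-lasting compound.

On these data alone, the full size of the step remains open, as does whether it comes from losing the ring or from the carbamoylmethyl group itself. It is also unknown whether a plain methyl, a longer chain or an amine on this carbon would give a half-life closer to that of compound 2.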